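Inverting the second stereocentre of a kinase inhibitor

The source may hold more compounds than are shown below. What is called first, only, known or untested is meant among the compounds shown, and "the series" means these compounds.

Compound 1: `COc1ccc2c(c1)C[C@@H](C(=O)Nc1ccc(-c3cn[nH]c3)cc1O[C@@H]1CCN(C)C1)CO2` — > 20000 nM
Compound 2: `COc1ccc2c(c1)C[C@H](C(=O)Nc1ccc(-c3cn[nH]c3)cc1O[C@@H]1CCN(C)C1)CO2` — 261 nM

Within the data shown here, compound 2 is the only compound with a number in an assay on isolated protein for inhibition of serine/threonine-protein kinase MRCK alpha (Homo sapiens), read by luminescence, with a stated time of 75 min; on this read-out higher numbers stand for weaker inhibition and lower numbers for stronger inhibition. Compound 1 reaches only a limit in this assay, > 20000 nM. The step of an at least 76-fold lower number from compound 1 to compound 2 (1.88 log units; beyond the scatter) shows that changing one stereo element can move the result strongly, a reading supported by the limit of > 20000 nM in this assay, at which 1 of the 2 values shown sits, and (the fact that compounds 1 and 2 differ only in the configuration as drawn).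

Compound 3, `COc1ccc2c(c1)C[C@H](C(=O)Nc1ccc(-c3cn[nH]c3)cc1O[C@H]1CCN(C)C1)CO2`, differs from compound 2 at the other stereo element: the two compounds have the same atoms and bonds and differ only in configuration as drawn: 1 of 2 stereo elements differ; a stereocentre at a saturated ring carbon is drawn R in compound 2 and S in compound 3. Among the measured compounds shown here, no measured step touches this stereocentre, so the step to compound 3 has no direct precedent; the measured step only shows that configuration matters here. An expected change is therefore uncertain, leaning toward weaker inhibition. Compound 3 is estimated at 900 nM, with a range of 150 nM to 20000 nM, meaning an expected step of a 3.4-fold higher number from compound 2 to compound 3 (0.54 log units; beyond the scatter).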

Compound 3, half-maximal inhibitory concentration: 294 nM
Estimate against measurement, compound 3: 3.1-fold (0.49 log units) above, within the range that was stated.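

In this assay, inverting this stereocentre gives a 1.1-fold higher number from compound 2 to compound 3 (0.05 log units; within the scatter), so the configuration here leaves the result within the scatter, unlike the stereocentre changed in the earlier step. With both stereocentres inverted, the mirror-image pair gives an at least 68-fold lower number from compound 1 to compound 3 (1.83 log units; beyond the scatter), and so the large loss seen earlier does not arise at this stereocentre when the other one is drawn as in compound 2 and compound 3. Compound 1 gives > 20000 nM, which is a limit and not a number.

Going by these compounds, how this stereocentre behaves when the other one is drawn as in compound 1 stays open. Also open, on these data alone, is whether a primary amine or a longer chain at this place would leave the result equally unchanged.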